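The source may report more compounds than this note shows. Statements on the series, on what has been measured and on what is new or still open speak of the compounds shown alone.

Measured so far in a functional assay on QG-56 cells (Homo sapiens) for cytotoxicity, read by MTT assay, with a stated time of 48 h; on this read-out higher numbers stand for weaker inhibition and lower numbers for stronger inhibition:
- compound 1 `COc1cc(/C=C/C(=O)C2=C(/C=C/c3ccc(O)c(OC)c3)NC(=O)NC2c2ccc(C)cc2)ccc1O`: 100000000 nM
- compound 2 `COc1cc(/C=C/C(=O)C2=C(/C=C/c3ccc(O)c(OC)c3)NC(=O)NC2c2ccc(O)cc2)ccc1O`: 50000000 nM

Among the measured compounds shown here, compound 2 stands within the scatter of compound 1, the only other measured compound, with a 2.0-fold lower number from compound 1 to compound 2 (0.30 log units; within the scatter). Next is compound 3 `COc1cc(/C=C/C(=O)C2=C(/C=C/c3ccc(O)c(OC)c3)NC(=O)NC2c2ccccc2)ccc1O`, with hydrogen in place of hydroxy on an aromatic carbon, para to a large group. For the measured compounds named here, the one measured step at this place, methyl to hydroxy, is a 2.0-fold lower number from compound 1 to compound 2 (0.30 log units; within the scatter), so no change beyond the scatter is expected in this assay. The expected step is a 1.4-fold higher number from compound 2 to compound 3 (0.15 log units; within the scatter). For compound 3 the estimate is 70000000 nM, with an expected range of 30000000 nM to 150000000 nM.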

Compound 3, half-maximal inhibitory concentration: 50000000 nM
Beside the measured number, compound 3's estimate is 1.4-fold (0.15 log units) above it, and the stated range covers the measured number.
By their numbers in this assay, from the lowest: compounds 2, 3 and 1 (each within the scatter of the next).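

In this assay the change from hydroxy to hydrogen gives no change at the digits printed from compound 2 to compound 3 (within the scatter) and the change from methyl to hydrogen gives a 2.0-fold lower number from compound 1 to compound 3 (0.30 log units; within the scatter) so hydrogen, hydroxy and methyl cannot be told apart at this place, para to a large group. The bare phenyl adds the unsubstituted reference that the earlier pair lacked, and the read-out separates it from neither substituted compound. No evidence is available to explain this flat result.

Going by these compounds, whether an amine, a carboxylic acid or a longer chain such as butoxy at this place would give a step beyond the scatter remains open. Also open, on these data alone, is whether changes elsewhere on the shared core would move the number at all.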